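Trimming one methoxy group from the ketone-side ring

The source may hold more compounds than are shown below. What is called first, only, known or untested is meant among the compounds shown, and "the series" means these compounds.

Three measured compounds share one core. Compound 1 `COc1cc(C(=O)/C=C/c2cc(-c3cc(OC)c(OC)c(OC)c3)n3nc(-c4ccccc4)cc3n2)cc(OC)c1OC` gives 20500 nM in a functional assay on A549 cells (Homo sapiens) for antiproliferative activity, read by MTT assay, with a stated time of 24 h; a lower number here means a stronger inhibitor, a higher number a weaker inhibitor. Compound 2 `COc1ccc(-c2cc(/C=C/C(=O)c3cc(OC)c(OC)c(OC)c3)nc3cc(-c4ccccc4)nn23)cc1OC` gives 7200 nM, and compound 3 `COc1cc(-c2cc(C(=O)/C=C/c3ccccc3)nc3cc(-c4ccccc4)nn23)cc(OC)c1OC` gives 18000 nM. Compound 2 thus has the lowest number of the three, and its gaps to compound 3 and to compound 1 both lie beyond the usual scatter.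

Compound 4 `COc1ccc(C(=O)/C=C/c2cc(-c3ccc(OC)c(OC)c3)n3nc(-c4ccccc4)cc3n2)cc1OC` is not yet measured. It differs from compound 2 by hydrogen in place of methoxy on an aromatic carbon, so the 3,4,5-trimethoxyphenyl attached to the carbonyl becomes a 3,4-dimethoxyphenyl. Among the measured compounds shown here, the only single-point step measured, a 2.8-fold lower number from compound 1 to compound 2 (0.45 log units; beyond the scatter), concerns the other aryl ring, the one attached to the core, and so bears only loosely on this change. Compound 1 and compound 3 differ on the ketone-side ring, and the value of compound 1 at 20500 nM and that of compound 3 at 18000 nM sit within the scatter of each other, which suggests that methoxy groups on that ring matter little. The expected step of a 1.1-fold higher number from compound 2 to compound 4 (0.05 log units; within the scatter) is therefore small, close to none beyond the scatter. Compound 4 is estimated at 8000 nM, with a range from 3500 nM to 18000 nM.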

Compound 4, half-maximal inhibitory concentration: 3900 nM
Estimate against measurement, compound 4: 2.1-fold (0.31 log units) above; measured number inside the range.
By their numbers in this assay, from the lowest: compounds 4 and 2 (each within the scatter of the next); then compounds 3 and 1 (each within the scatter of the next).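

Replacing methoxy with hydrogen on the ring attached to the carbonyl, which turns the 3,4,5-trimethoxyphenyl into a 3,4-dimethoxyphenyl, gives a 1.8-fold lower number from compound 2 to compound 4 (0.27 log units; within the scatter) in this assay. Among the compounds shown here, this is the first direct single-place reading at this ring, and it shows that this methoxy group can be lost without a change that stands out from the scatter of repeated measurements. The same exchange on the aryl ring attached to the core gives a 2.8-fold lower number from compound 1 to compound 2 (0.45 log units; beyond the scatter), so of these two pairs only that one reads beyond the scatter, and no measurement at hand offers a reason for either result.

Still open, from the compounds shown here alone, is how a hydroxyl group, a fluorine atom or an amine would read at this place, in the position of the lost methoxy group.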